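Chain change from compound 2 to compound 3

The source may report more compounds than this note shows. Statements on the series, on what has been measured and on what is new or still open speak of the compounds shown alone.

Among the measured compounds shown here, in a functional assay (strain AB) with Danio rerio as the target, read by microscopy, with a stated time of 1 h (a higher number here means that more compound is needed for the effect, a lower number that less compound is needed), compound 1 `CC(C)(C)OC(=O)CCCCC[N+]1(C)CCc2c(sc(NC(=O)Nc3ccc(Cl)cc3)c2C(N)=O)C1` gives 110 nM and compound 2 `C[N+]1(CC2CC2)CCc2c(sc(NC(=O)Nc3ccc(Cl)cc3)c2C(N)=O)C1` gives 360 nM as the higher of the two numbers so far. For the measured compounds named here, the only measured step is a 3.3-fold higher number from compound 1 to compound 2 (0.51 log units; beyond the scatter) and it puts cyclopropyl in place of 4-(tert-butoxycarbonyl)butyl on a saturated chain carbon bound to an amine nitrogen in a ring.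

Compound 3 `COCCC[N+]1(C)CCc2c(sc(NC(=O)Nc3ccc(Cl)cc3)c2C(N)=O)C1` is still unmeasured. Its difference from compound 2 is 2-methoxyethyl in place of cyclopropyl on a saturated chain carbon bound to an amine nitrogen in a ring and amounts to 2-methoxyethyl in place of cyclopropyl at that same place. Cut one bond further out, the change reads cyclopropylmethyl to 3-methoxypropyl.

Like compound 1 at 110 nM in this assay compound 3 has no ring in this group, so a part of the gap to compound 2 is expected to close. Going by the values given here, the entering group is not the one in compound 1, and a single step gives thin support. The expected change is a 1.4-fold lower number from compound 2 to compound 3 (0.16 log units; within the scatter) and it leans toward a lower number without being expected to clear the scatter. For compound 3 the estimated value is 250 nM (expected range 90 nM to 700 nM).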

Compound 3, half-maximal effective concentration: 480 nM
Compound 3: the middle estimate sits 1.9-fold (0.28 log units) below what was measured; low and high end bracket the measured number.
By their numbers in this assay, from the lowest: compound 1; then compounds 2 and 3 (each within the scatter of the next).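

In this assay, losing the ring from this group does not by itself move the number toward that of compound 1: the step is a 1.3-fold higher number from compound 2 to compound 3 (0.12 log units; within the scatter) with 2-methoxyethyl in place of cyclopropyl, so these two groups are not told apart at this position. The distance from the long ester chain remains, at a 4.4-fold higher number from compound 1 to compound 3 (0.64 log units; beyond the scatter) with methoxy in place of 2-(tert-butoxycarbonyl)ethyl, and because compound 3 also has no ring in this group, the absence of a ring does not separate compound 1 from the other two compounds. No measurement at hand accounts for what sets the chain of compound 1 apart from the other two groups.

The compounds shown leave open whether the lower number of compound 1 goes with the length of its chain or with the tert-butoxycarbonyl end. A plain alkyl chain as long as that of compound 1, and the same chain ending in a carboxylic acid or an amine, would bear on that question in this assay.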